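The compounds below may be only part of what the source reports. "The series", "measured", "known", "first", "only" and "open" are said of these compounds alone.

Measured compounds in a functional assay on HepG2 cells (Homo sapiens) for cytotoxicity, read by sulforhodamine B assay, with a stated time of 72 h; on this read-out higher numbers stand for weaker inhibition and lower numbers for stronger inhibition:
- compound 1 `CCOC(=O)c1nn(-c2ccc(C)cc2)/c(=N/c2nc(-c3c(C)n(C)n(-c4ccccc4)c3=O)cs2)s1`: compound 1 gives > 100000 nM
- compound 2 `CCOC(=O)c1nn(-c2ccc(OC)cc2)/c(=N/c2nc(-c3c(C)n(C)n(-c4ccccc4)c3=O)cs2)s1`: compound 2 gives 12900 nM
- compound 3 `COc1ccc(/C=C2\S/C(=N\c3nc(-c4c(C)n(C)n(-c5ccccc5)c4=O)cs3)N(c3ccccc3)C2=O)cc1`: compound 3 gives 13200 nM

The value for compound 1 is a limit of this assay, not a number; it sits at the limit of > 100000 nM in this assay, at which 1 of the 3 values shown sits. Compound 1 and compound 2 share a core and differ only by methyl in place of methoxy on an aromatic carbon, the step being an at least 7.7-fold higher number from compound 2 to compound 1 (0.88 log units; beyond the scatter). Compound 3 is built on a different core; the difference between the two cores is not broken down here. The values of compound 2 and compound 3 lie within the scatter of each other, so no order is read between them.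

Compound 4 `Cc1ccc(/C=C2\S/C(=N\c3nc(-c4c(C)n(C)n(-c5ccccc5)c4=O)cs3)N(c3ccccc3)C2=O)cc1` is not yet measured. It differs from compound 3 by methyl in place of methoxy on an aromatic carbon, the same change as that from compound 2 to compound 1, at the same place as described there. Taken on the core of compound 3, whose value is close to that of compound 2, the expectation for compound 4 is a step of a 4.5-fold higher number from compound 3 to compound 4 (0.66 log units; beyond the scatter), resting on the measured step of an at least 7.7-fold higher number from compound 2 to compound 1 (0.88 log units; beyond the scatter) in the other core. On these data alone, because that step only reached a limit, its true size is unknown, and the carry-over between cores is untested, so the range is kept wide. Compound 4 is expected to give 60000 nM in this assay, with a span of 15000 nM to 150000 nM, and a fair chance that only a limit is reported.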

Compound 4, half-maximal inhibitory concentration: > 100000 nM
Compound 4 gave a limit, no number (the forecaster's own chance of this, stated with the estimate: 45%); middle value at least 1.6-fold (0.22 log units) away from the limit.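

In this assay compound 4 gives > 100000 nM, which is a limit of the assay and not a number. On the core of compound 3, the change from 4-methoxyphenyl to 4-methylphenyl gives an at least 7.5-fold higher number from compound 3 to compound 4 (0.87 log units; beyond the scatter), so in both pairs shown the methyl compound reads weaker than its methoxy partner, and neither pair goes against this direction: the same change on two cores in this assay, an at least 7.7-fold higher number (0.88 log units; beyond the scatter) from compound 2 to compound 1 and an at least 7.5-fold higher number (0.87 log units; beyond the scatter) from compound 3 to compound 4; the limit leaves it open whether they differ What carries over between the two cores is therefore the direction and a minimum size, not a true size, and two pairs say nothing about cores beyond these, since both methyl compounds stop at the same limit: the limit of > 100000 nM in this assay, at which 2 of the 4 values shown sit.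

The compounds shown leave open whether the methoxy group is specifically favoured or whether other groups in the same place, such as hydroxyl, ethoxy, chlorine or dimethylamino, or plain hydrogen, would read like compound 2 and compound 3 or like compound 1 and compound 4. Also open, on these data alone, is whether the same change behaves alike on a third core, and how far the methyl compounds lie past the limit.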